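The source may report more compounds than this note shows. Statements on the series, on what has been measured and on what is new or still open speak of the compounds shown alone.

Working notes on the series. In a functional assay on a cell-free system (plasma, Homo sapiens), with a stated time of 3 min (a higher number here means a weaker inhibitor, a lower number a stronger inhibitor), compound 1 (`O=C(NCc1cc(Cl)ccc1-n1cnnn1)[C@@H]1C[C@@H]2C[C@@H]2N1C(=O)[C@H](O)c1cccc(Cl)c1`) reads 1000 nM, and compound 2 (`CC(C)(C)[C@@H](O)C(=O)N1N=CC[C@H]1C(=O)NCc1cc(Cl)ccc1-n1cnnn1`) at 1400 nM and compound 3 (`CC(C)(C)C[C@@H](O)C(=O)N1OCC[C@H]1C(=O)NCc1cc(Cl)ccc1-n1cnnn1`) at 1100 nM both lie within the scatter of it, so the three numbers give no order.

Compound 4 (`O=C(NCc1cc(Cl)ccc1-n1cnnn1)[C@@H]1C[C@@H]2C[C@@H]2N1C(=O)[C@H](O)c1ccccc1`) is still unmeasured. It keeps the core of compound 1 and carries hydrogen in place of chloro on an aromatic carbon, which turns the 3-chlorophenyl into phenyl.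

Within the data shown here, no measured pair isolates this change, so no step can be carried over directly. The nearest indirect evidence is weak: compound 2 with 1400 nM and compound 3 with 1100 nM both lack the 3-chlorophenyl group, and both also differ from compound 1 elsewhere. Their numbers give no reason to expect a large step in this assay. A small shift toward a weaker inhibitor is expected, at about the edge of the scatter, though no change beyond the scatter remains possible. The estimated size of this shift is a 1.8-fold higher number from compound 1 to compound 4 (0.26 log units; within the scatter) on current evidence. For compound 4 the estimated value is 1800 nM with an expected range from 700 nM to 5000 nM as a working figure.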

Compound 4, half-maximal inhibitory concentration: 620 nM
The estimate for compound 4 lay 2.9-fold (0.46 log units) above the measured number; measured number outside the range, below it.
By their numbers in this assay, from the lowest: compounds 4, 1, 3 and 2 (each within the scatter of the next, the first and the last beyond it).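

Among these compounds, the pair compound 1 and compound 4 gives the first direct reading of hydrogen in place of chloro on an aromatic carbon, at the place meta to a large group on the six-membered aromatic ring of carbon only, which the earlier compounds could only approach through differences elsewhere. In this assay the step is a 1.6-fold lower number from compound 1 to compound 4 (0.21 log units; within the scatter) and so the two compounds cannot be told apart, with the shared core held constant. On this core, then, the chloro at this place is not required for a number of this size, and the 3-chlorophenyl and the phenyl read alike here, while no measurement offers an explanation for this result.

On these data alone, whether a different group at this place, such as methoxy, trifluoromethyl or an amine, would give a step beyond the scatter remains open, since a single exchange to hydrogen does not define what the position tolerates. Also open, as far as these compounds go, is how the same exchange reads at the chloro on the other aromatic ring, which all four compounds carry, and whether the result holds on the cores of compound 2 and compound 3.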